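Amine variation on the shared core: cytotoxicity outlook

This account rests on a few compounds, and the source may have more. Where it says the series, first, only, none or still open, it means among the compounds named here.

Compound 3 `CCN(CC)c1nc(=O)c2cc(C(F)(F)F)cc([N+](=O)[O-])c2s1` carries a diethylamino group on the core that compound 1 `CCNc1nc(=O)c2cc(C(F)(F)F)cc([N+](=O)[O-])c2s1` and compound 2 `CCCNc1nc(=O)c2cc(C(F)(F)F)cc([N+](=O)[O-])c2s1` share. In an ADME assay on Vero cells (Chlorocebus sabaeus) for cytotoxicity, read by MTT assay, with a stated time of 72 h (on this read-out higher numbers stand for weaker inhibition and lower numbers for stronger inhibition), compound 3 reports only a limit of the assay, > 100000 nM. In this assay compound 1 likewise reports only a limit, > 100000 nM. In this assay compound 2 also reports only a limit, > 100000 nM. The three measured steps are therefore unreadable: a step that the two limits leave unreadable from compound 1 to compound 2, a step that the two limits leave unreadable from compound 1 to compound 3 and a step that the two limits leave unreadable from compound 2 to compound 3. All that the series shows is the limit of > 100000 nM in this assay, at which 3 of the 3 values shown sit, so compound 3 stands where every measured compound stands, at that limit.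

Compound 4 `O=c1nc(NC2CC2)sc2c([N+](=O)[O-])cc(C(F)(F)F)cc12` differs from compound 3 by cyclopropylamino in place of diethylamino on an aromatic carbon. Among the compounds with values here, no measured step in this assay gives a readable size for a change of this kind, and the only evidence is the limit of > 100000 nM in this assay, at which 3 of the 3 values shown sit. Compound 4 is therefore expected to sit at or near the same limit, an estimated step that the limit leaves unreadable from compound 3 to compound 4. The estimate for compound 4 in this assay is 150000 nM, with a range from 60000 nM to 400000 nM.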

Compound 4, half-maximal inhibitory concentration: > 100000 nM
Compound 4 was reported as a limit; the forecaster's own chance of this, stated with the estimate: 85%; the middle value lies beyond the limit too.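

No step can be read from compound 4 to compound 1, compound 2 or compound 3 in this assay, as each pair rests on two limits: the limit of > 100000 nM in this assay, at which 4 of the 4 values shown sit. The compounds shown leave open whether any amine group on the shared core gives a readable value in this assay.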